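The source may report more compounds than this note shows. Statements on the series, on what has been measured and on what is new or still open speak of the compounds shown alone.

Compound 2 `CCOC(=O)C1CCN(C(=O)CN2CN(c3ccccc3)C3(CCN(C(=O)c4ccc(C(C)(C)C)cc4)CC3)C2=O)CC1` gives 3100 nM in an assay on HEK293 cells for displacement of a labelled ligand from NPC1-like intracellular cholesterol transporter 1 (Homo sapiens); a lower number here means a stronger inhibitor, a higher number a weaker inhibitor. Among the three compounds measured so far it stands second highest. Its nearest neighbour is compound 1 `CC(C)(C)c1ccc(C(=O)N2CCC3(CC2)C(=O)N(CC(=O)N2CCC(CCO)CC2)CN3c2ccccc2)cc1`, which gives 2600 nM in this assay; the exchange between them, a 1.2-fold higher number from compound 1 to compound 2 (0.08 log units; within the scatter), sits within the scatter, so the two cannot be told apart. The furthest is compound 3 `CC(C)(C)c1ccc(C(=O)N2CCC3(CC2)C(=O)N(CC(=O)NCCCCO)CN3c2ccccc2)cc1`, which gives 19200 nM; the change a 6.2-fold higher number from compound 2 to compound 3 (0.79 log units; beyond the scatter) lies beyond the scatter, as does a 7.4-fold higher number from compound 1 to compound 3 (0.87 log units; beyond the scatter).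

Compound 4 `CC(C)(C)OC(=O)NCC1CCN(C(=O)CN2CN(c3ccccc3)C3(CCN(C(=O)c4ccc(C(C)(C)C)cc4)CC3)C2=O)CC1` has not yet been measured. It differs from compound 2 in one place: ((tert-butoxycarbonyl)amino)methyl in place of ethoxycarbonyl on a saturated ring carbon. The exchange already seen on that same saturated ring carbon, a 1.2-fold higher number from compound 1 to compound 2 (0.08 log units; within the scatter), barely moved the number. The two larger changes, a 7.4-fold higher number from compound 1 to compound 3 (0.87 log units; beyond the scatter) and a 6.2-fold higher number from compound 2 to compound 3 (0.79 log units; beyond the scatter), belong to a different kind of edit, in which the six-membered ring itself is replaced by an open chain, and so they say little about a new group hanging from that ring. The new group is bulkier and carries one hydrogen-bond donor, but nothing measured here shows what such a group does at this position.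

Compound 4 is therefore expected to give about 3500 nM in this assay, with a range from 1500 nM to 8500 nM. That estimate means a step of a 1.1-fold higher number from compound 2 to compound 4 (0.05 log units; within the scatter), expected to stay within the scatter.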

Compound 4, half-maximal inhibitory concentration: 4200 nM
Beside the measured number, compound 4's estimate is 1.2-fold (0.08 log units) below it; the range from low to high includes it.
By their numbers in this assay, from the lowest: compounds 1, 2 and 4 (each within the scatter of the next); then compound 3.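

In this assay, placing ((tert-butoxycarbonyl)amino)methyl in place of ethoxycarbonyl on this saturated ring carbon gives a 1.4-fold higher number from compound 2 to compound 4 (0.13 log units; within the scatter), even though the entering group has 9 heavy atoms against 5 and carries 1 hydrogen-bond donor where the leaving group has none. The comparison with the 2-hydroxyethyl group of compound 1 reads the same way, with a 1.6-fold higher number from compound 1 to compound 4 (0.21 log units; within the scatter) also within the scatter, so the earlier single pair has grown to three different groups on this carbon, in compounds 1, 2 and 4, that cannot be told apart in this assay. No measurement at hand explains why these exchanges leave the number so little changed.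

Still open, on these data alone, is whether this insensitivity extends to other kinds of group on the same ring carbon, such as a free aminomethyl, a carboxylic acid or a plain hydrogen. A much longer chain or an added aromatic ring there is equally untested in the compounds shown, so any of these could yet move the number beyond the scatter, or leave it where it is.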